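Benzofuranyl for thiophenyl on two nucleoside cores

The source may report more compounds than this note shows. Statements on the series, on what has been measured and on what is new or still open speak of the compounds shown alone.

Compound 1 `Nc1nc2c(c(-c3cccs3)cn2[C@@H]2O[C@H](CO)[C@@H](O)[C@H]2O)c(=O)[nH]1` and compound 2 `CN(C)c1ncnc2c1c(-c1cccs1)cn2[C@@H]1O[C@H](CO)[C@@H](O)[C@H]1O` carry the same sugar on two different cores; the difference between the two cores is not broken down here. In a functional assay on HeLa S3 cells (Homo sapiens) for antiproliferative activity, read by XTT assay, with a stated time of 72 h (on this read-out lower numbers stand for stronger inhibition and higher numbers for weaker inhibition), compound 1 gives > 20000 nM, which is a limit of the assay and not a number. In this assay compound 2 gives > 20000 nM, also a limit. Compound 3 `Nc1nc2c(c(-c3cc4ccccc4o3)cn2[C@@H]2O[C@H](CO)[C@@H](O)[C@H]2O)c(=O)[nH]1` arises from compound 1 by 1-benzofuran-2-yl in place of thiophen-2-yl on an aromatic carbon. In this assay compound 3 gives > 20000 nM, again a limit. The step that the two limits leave unreadable from compound 1 to compound 3 therefore cannot be sized, because the limit of > 20000 nM in this assay, at which 3 of the 3 values shown sit, fixes both ends at the same limit. Compound 4 `CN(C)c1ncnc2c1c(-c1cc3ccccc3o1)cn2[C@@H]1O[C@H](CO)[C@@H](O)[C@H]1O` is the unmeasured analogue of compound 2 carrying (1-benzofuran-2-yl in place of thiophen-2-yl on an aromatic carbon), the same change at the same place as from compound 1 to compound 3. With the first step unreadable and compound 2 already at the limit, the step that the limit leaves unreadable from compound 2 to compound 4 is expected for compound 4, resting on (the limit of > 20000 nM in this assay, at which 3 of the 3 values shown sit). Compound 4 is expected at 30000 nM, between 10000 nM and 100000 nM, most likely reported as a limit.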

Compound 4, half-maximal inhibitory concentration: > 20000 nM
Compound 4 was reported as a limit (the forecaster's own chance of this, stated with the estimate: 85%); the middle value is on the limit's open side.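

In this assay compound 4 gives > 20000 nM, a limit of the assay and not a number. No step can be read from compound 2 to compound 4, because both ends sit at the same limit: the limit of > 20000 nM in this assay, at which 4 of the 4 values shown sit. The compounds shown leave open how thiophen-2-yl and 1-benzofuran-2-yl compare on either core in this assay.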